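Para substituent swap on the aryl ring of compound 3

This account rests on a few compounds, and the source may have more. Where it says the series, first, only, none or still open, it means among the compounds named here.

Measured so far:
- compound 1 `CCC(=O)N1N=C(c2ccccc2)CC1c1ccc(C)cc1`: 100000 nM
- compound 2 `CCC(=O)N1N=C(c2ccc(F)cc2)CC1c1ccccc1`: 200 nM
- compound 3 `CCC(=O)N1N=C(c2ccc(F)cc2)CC1c1ccc(Cl)cc1`: 6310 nM

In an assay on isolated protein for inhibition of Amine oxidase [flavin-containing] B (Bos taurus) (a lower number here means a stronger inhibitor, a higher number a weaker inhibitor), compound 3 gives 6310 nM, the second highest of the three numbers; it sits nearer to compound 1 than to compound 2, and the step of a 32-fold higher number from compound 2 to compound 3 (1.50 log units; beyond the scatter) shows that placing chloro on that ring costs a great deal relative to the unsubstituted analogue.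

Compound 4 `CCC(=O)N1N=C(c2ccc(F)cc2)CC1c1ccc(C)cc1` is not yet measured. It differs from compound 3 by methyl in place of chloro on an aromatic carbon. Going by the values given here, the only measured step that bears on this position is a 32-fold higher number from compound 2 to compound 3 (1.50 log units; beyond the scatter), which is large and shows the para position on this ring to be sensitive to a substituent. Among the compounds with values here, compound 1 carries the same 4-methylphenyl but lacks the fluorine, so its value gives no step to compound 4. Since methyl is a single heavy atom in the same place as chloro, a step of similar size in either direction is not supported by the data; compound 4 is therefore expected to stay close to compound 3, with the estimated step of a 1.1-fold lower number from compound 3 to compound 4 (0.02 log units; within the scatter). The estimate for compound 4 is 6000 nM, within 1200 nM to 30000 nM.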

Compound 4, half-maximal inhibitory concentration: 151 nM
Beside the measured number, compound 4's estimate is 40-fold (1.60 log units) above it; the measured number lies below the stated range.
By their numbers in this assay, from the lowest: compounds 4 and 2 (each within the scatter of the next); then compound 3; then compound 1.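

In this assay, the change from 4-chlorophenyl to 4-methylphenyl gives a 42-fold lower number from compound 3 to compound 4 (1.62 log units; beyond the scatter), so the sensitivity at this place, para to a large group, depends on which group sits there and does not apply to every substituent. Methyl in place of hydrogen gives a 1.3-fold lower number from compound 2 to compound 4 (0.12 log units; within the scatter), so methyl is tolerated here where chloro is not. With 4-methylphenyl held constant, fluoro in place of hydrogen gives a 660-fold lower number from compound 1 to compound 4 (2.82 log units; beyond the scatter), which shows that this second site also has a large effect on the number.

No measurement at hand explains the wide gap between chloro and methyl. Going by these compounds, it remains open whether a methoxy group, an amine or a longer chain at this place would track methyl or chloro.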